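Hydroxy for chloro on an aryl acylhydrazone in cytotoxicity

The source may hold more compounds than are shown below. What is called first, only, known or untested is meant among the compounds shown, and "the series" means these compounds.

Compound 1 `O=C(CSc1nnnn1-c1cccc2ccccc12)N/N=C/c1cccc(Cl)c1`: 240000 nM in an ADME assay on MT4 cells (Homo sapiens) for cytotoxicity, read by MTT assay; on this read-out lower numbers stand for higher toxicity in this test and higher numbers for lower toxicity in this test.
Compound 2 `O=C(CSc1nnnn1-c1cccc2ccccc12)N/N=C/c1ccc(F)cc1`: in this assay compound 2 gives only a limit, > 307000 nM.
Compound 3 `COc1cccc(/C=N/NC(=O)CSc2nnnn2-c2cccc3ccccc23)c1OC`: 192000 nM in this assay.

Compound 1 holds the highest of the two numbers in this assay; compound 3 lies at a 1.3-fold lower number from compound 1 to compound 3 (0.10 log units; within the scatter), and compound 2 sits at the limit (the limit of > 307000 nM in this assay, at which 1 of the 3 values shown sits). Compound 4 `O=C(CSc1nnnn1-c1cccc2ccccc12)N/N=C/c1cccc(O)c1` differs from compound 1 in one place: hydroxy in place of chloro on an aromatic carbon. Among the measured compounds shown here, no measured step exchanges chloro for hydroxy. The three measured steps all change the group on the carbon with a double bond to nitrogen: an at least 1.2-fold higher number from compound 1 to compound 2 (0.10 log units; that floor lies within the scatter), a 1.3-fold lower number from compound 1 to compound 3 (0.10 log units; within the scatter) and an at least 1.5-fold lower number from compound 2 to compound 3 (0.20 log units; that floor lies within the scatter). None of them leaves the scatter, so this part of the shared core has so far tolerated quite different groups without a clear shift in this assay. The step of no change at the digits printed from compound 1 to compound 4 (within the scatter) is therefore expected to stay within the scatter. Compound 4 is expected to give about 240000 nM in this assay, with a range from 120000 nM to 400000 nM.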

Compound 4, half-maximal cytotoxic concentration: 169000 nM
Estimate against measurement, compound 4: 1.4-fold (0.15 log units) above, within the range that was stated.
By their numbers in this assay, from the lowest: compounds 4, 3 and 1 (each within the scatter of the next). At a limit, above all of these: compound 2.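

Hydroxy in place of chloro puts a hydrogen-bond donor and acceptor on this aromatic carbon, yet it gives a 1.4-fold lower number from compound 1 to compound 4 (0.15 log units; within the scatter), so this exchange adds no clear shift in this assay. Compound 4 also gives a 1.1-fold lower number from compound 3 to compound 4 (0.06 log units; within the scatter), and an at least 1.8-fold lower number from compound 2 to compound 4 (0.25 log units; that floor lies within the scatter). That last step is only a floor, as compound 2 gives a limit and not a number: the limit of > 307000 nM in this assay, at which 1 of the 4 values shown sits.

On these data alone, it remains open whether an amine or a carboxylic acid on this aromatic carbon would leave the scatter in this assay. Also open, as far as these compounds go, is how the read-out responds to changes in the shared core away from this ring, such as a longer chain.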